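This account rests on a few compounds, and the source may have more. Where it says the series, first, only, none or still open, it means among the compounds named here.

Compound 1 `Cn1nnnc1SCC(=O)N/N=C/c1ccccc1` gives 3160000 nM in a functional assay on A549 cells (Homo sapiens) for cytotoxicity, read by XTT assay, with a stated time of 24 h; on this read-out higher numbers stand for weaker inhibition and lower numbers for stronger inhibition. Compound 2 `Cn1nnnc1SCC(=O)N/N=C/c1ccc(O)cc1` reaches only a limit of this assay, > 10000000 nM.

Within the data shown here, compound 1 holds the only number; the other value is a limit. Compound 3 `Cn1nnnc1SCC(=O)N/N=C/c1ccccc1[N+](=O)[O-]` differs from compound 1 by nitro in place of hydrogen on an aromatic carbon. Among the measured compounds shown here, the one measured change on this ring, an at least 3.1-fold higher number from compound 1 to compound 2 (0.50 log units; beyond the scatter), ran to the limit of > 10000000 nM in this assay, at which 1 of the 2 values shown sits, but it put a hydroxy there, not a nitro, so it bears on compound 3 only loosely. Compound 3 is therefore expected near compound 1, the step of a 1.3-fold higher number from compound 1 to compound 3 (0.10 log units; within the scatter) small and uncertain. The estimate for compound 3 is 4000000 nM, between 1500000 nM and 10000000 nM.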

Compound 3, half-maximal inhibitory concentration: 1600000 nM
Compound 3: middle estimate off by 2.5-fold (0.40 log units), on the high side, within the range that was stated.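

In this assay, nitro in place of hydrogen, ortho to a large group, gives a step of a 2.0-fold lower number from compound 1 to compound 3 (0.30 log units; within the scatter). This shows that this ring carbon can carry a group of 3 heavy atoms with no change beyond the scatter, and the result stays a measured number. Compound 2, by contrast, remains a limit and not a number: the limit of > 10000000 nM in this assay, at which 1 of the 3 values shown sits.

The compounds shown leave open whether an amine, a methoxy group or a carboxylic acid at this same place would move the number beyond the scatter. They also leave open whether nitro on another carbon of this ring would behave the same way.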